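This account rests on a few compounds, and the source may have more. Where it says the series, first, only, none or still open, it means among the compounds named here.

Compounds measured in a functional assay for inhibition, with Homo sapiens as the target; a lower number here means tighter binding, a higher number weaker binding:
compound 1, `O=C(O)CC/C=C\CC1COC(c2ccccc2Cl)OC1c1cccnc1`: 759 nM
compound 2, `O=C(O)CC/C=C\CC1COC(c2ccc([N+](=O)[O-])cc2)OC1c1cccnc1`: 933 nM
compound 3, `O=C(O)CC/C=C\CC1COC(c2ccc(Cl)cc2Cl)OC1c1cccnc1`: 891 nM

In this assay compound 2 gives 933 nM. The numbers for compound 1 and compound 3 lie within the usual scatter of that value, so none of the three can be set apart from the others on what has been measured.

The unmeasured compound 4, `O=C(O)CC/C=C\CC1COC(c2ccc3ccccc3c2)OC1c1cccnc1`, differs from compound 2 in one place: naphthalen-2-yl in place of 4-nitrophenyl on a saturated ring carbon. For the measured compounds named here, two measured steps concern the same saturated ring carbon, an exchange of the aromatic group that sits between the two ring oxygen atoms: a 1.2-fold higher number from compound 1 to compound 2 (0.09 log units; within the scatter) and a 1.0-fold lower number from compound 2 to compound 3 (0.02 log units; within the scatter). The third, a 1.2-fold higher number from compound 1 to compound 3 (0.07 log units; within the scatter), touches an aromatic carbon and bears on the present change only indirectly. All three steps fall within the scatter. The naphthalen-2-yl group does not appear among the measured compounds, so no data speak to it directly; the expectation rests on the exchanges seen so far at this position. On that basis no step beyond the scatter is expected, a 1.0-fold lower number from compound 2 to compound 4 (0.02 log units; within the scatter). Compound 4 is therefore estimated at 900 nM, with a range from 350 nM to 2300 nM.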

Compound 4, dissociation constant: 1780 nM
Estimate against measurement, compound 4: 2.0-fold (0.30 log units) below; low and high end bracket the measured number.
By their numbers in this assay, from the lowest: compounds 1, 3, 2 and 4 (each within the scatter of the next, the first and the last beyond it).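

In this assay, exchanges of the aromatic group on the saturated ring carbon between two ring oxygen atoms now yield a step beyond the scatter, a 2.3-fold higher number from compound 1 to compound 4 (0.37 log units; beyond the scatter), though only a modest one, whereas all earlier steps stayed within it. The other two steps, a 1.9-fold higher number from compound 2 to compound 4 (0.28 log units; within the scatter) and a 2.0-fold higher number from compound 3 to compound 4 (0.30 log units; within the scatter), remain within the scatter, so the naphthalen-2-yl group is set apart from the 2-chlorophenyl group alone, not from the 4-nitrophenyl or 2,4-dichlorophenyl groups. No supporting data bear on this difference, and the step stands without an explanation.

As far as these compounds go, it remains open whether a single ring without chloro or nitro substituents, such as plain phenyl, or a saturated cyclohexyl group at this carbon would stay with the three phenyl-based compounds or move toward the naphthalen-2-yl compound. Also open, from the compounds shown here alone, is whether the same exchanges would give similar steps with a shorter chain in place of the 5-carboxypent-2-en-1-yl group, or with another group in place of the pyridin-3-yl group.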